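Amide versus urea on the shared core: dichloro step

The compounds below may be only part of what the source reports. "The series", "measured", "known", "first", "only" and "open" are said of these compounds alone.

Measured so far in a functional assay on SK-BR-3 cells (Homo sapiens) for inhibition, read by MTT assay, with a stated time of 2 days, tested at 10 uM; on this read-out lower numbers stand for less inhibition of growth and higher numbers for more inhibition of growth at the one concentration tested:
compound 1, `CNC(=O)c1cc(Oc2ccc3nc(NC(=O)Nc4cc(C(F)(F)F)cc(C(F)(F)F)c4)sc3c2)ccn1`, gives 88.1%
compound 2, `CNC(=O)c1cc(Oc2ccc3nc(NC(=O)c4ccc(Cl)cc4)sc3c2)ccn1`, gives 18.9%
compound 3, `CNC(=O)c1cc(Oc2ccc3nc(NC(=O)Nc4ccc(C5CCN(C(C)C)CC5)cc4)sc3c2)ccn1`, gives 45%

Compound 2 carries the lowest of the three numbers. Compound 3 stands nearest, with a number higher by a margin that lies beyond the scatter, and compound 1 stands furthest, higher by a margin well beyond the scatter. Compound 2 is the only amide here; compound 1 and compound 3 are ureas, and nothing measured separates the amide-to-urea switch from the change of the aryl group, so the two cannot be pulled apart on these numbers.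

The next compound is compound 4, `CNC(=O)c1cc(Oc2ccc3nc(NC(=O)c4cc(Cl)cc(Cl)c4)sc3c2)ccn1`. It differs from compound 2 as follows: 3,5-dichlorophenyl in place of 4-chlorophenyl on a carbonyl carbon. Among the measured compounds shown here, no single-change step between measured compounds exists for this pair, so no step size can be read from the data. The expected step from compound 2 to compound 4 is a number 13.1 percentage points higher from compound 2 to compound 4 (beyond the scatter) in this assay, an increase that may not clear the scatter. Compound 4 is estimated at 32%, with a range from 12% to 60%.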

Compound 4, percent growth inhibition at one concentration: 9.62%
Compound 4: the middle estimate sits 22.4 percentage points above what was measured; the whole stated range lies above it.
By their numbers in this assay, from the lowest: compounds 4 and 2 (each within the scatter of the next); then compound 3; then compound 1.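

In this assay, among the compounds shown here, the one single-change step so far is a number 9.3 percentage points lower from compound 2 to compound 4 (within the scatter) and it shows that 3,5-dichlorophenyl and 4-chlorophenyl on this carbonyl carbon cannot be told apart at the one concentration tested. For this position, the chlorine pattern on the phenyl ring of the amide therefore gives no readable difference between these two compounds, and the pair gives no basis for a trend across chlorine patterns. No measurement shown bears on why the two compounds cannot be separated.

Going by these compounds, the contribution of the amide-to-urea switch on its own stays open, since compound 2 and compound 4 each differ from the ureas in more than one place, and those comparisons cannot be read. Also open, on these data alone, is whether a dimethylamino group, a morpholine or a carboxylic acid on the phenyl ring of the amide would separate from the chlorinated compounds, since the two aryl groups compared here carry chlorine as their only substituent.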